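Swapping Chloro for Fluoro on a Dicyanoquinazoline-Type Core

The source may report more compounds than this note shows. Statements on the series, on what has been measured and on what is new or still open speak of the compounds shown alone.

Compound 1 `N#Cc1c(Nc2ccccc2)c(Cl)c2nc(N)nc(N)c2c1F` and compound 2 `N#Cc1c(Nc2ccccc2)c(F)c2nc(N)nc(N)c2c1F` differ in one place: fluoro in place of chloro on an aromatic carbon. In a functional assay on A-431 cells (Homo sapiens) for cytotoxicity, read by MTT assay (a lower number here means a stronger inhibitor, a higher number a weaker inhibitor), compound 1 gives 4.8 ug/mL, while compound 2 gives 7 ug/mL, a step of a 1.5-fold higher number from compound 1 to compound 2 (0.16 log units; within the scatter). Compound 3 `N#Cc1c(NCc2ccccc2)c(Cl)c2nc(N)nc(N)c2c1NCc1ccccc1` rests on a core whose difference from that of compound 1 is not broken down here; in this assay compound 3 gives 716 ug/mL, far above the other two. Compound 4 `N#Cc1c(NCc2ccccc2)c(F)c2nc(N)nc(N)c2c1NCc1ccccc1` is not yet measured and differs from compound 3 thus: fluoro in place of chloro on an aromatic carbon. This is the same kind of change as from compound 1 to compound 2, but the surroundings differ: the place is ortho to a benzylamino group and para to a benzylamino group, rather than ortho to an anilino group and para to a fluoro group. Because the earlier step was a 1.5-fold higher number from compound 1 to compound 2 (0.16 log units; within the scatter), a step of a 1.2-fold higher number from compound 3 to compound 4 (0.07 log units; within the scatter) is expected. Compound 4 is estimated at 850 ug/mL, between 300 ug/mL and 2500 ug/mL.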

Compound 4, half-maximal inhibitory concentration: 20.7 ug/mL
Beside the measured number, compound 4's estimate is 41-fold (1.61 log units) above it; measured number outside the range, below it.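

In this assay, fluoro in place of chloro on an aromatic carbon gives a step of a 35-fold lower number from compound 3 to compound 4 (1.54 log units; beyond the scatter), so on the core with two benzylamino groups the swap makes a large difference. The same change does not carry over in size from one core to the other: the same change on two cores in this assay, a 1.5-fold higher number (0.16 log units; within the scatter) from compound 1 to compound 2 and a 35-fold lower number (1.54 log units; beyond the scatter) from compound 3 to compound 4, 50-fold (1.70 log units) apart, beyond the scatter of two such steps

This shows that a step seen on one core cannot simply be assumed for the other, but two pairs give no general rule for the series, and they do not say which part of the cores accounts for the gap.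

Still open, from the compounds shown here alone, is how a bromo group, a methoxy group or an amine at this place would compare with chloro and fluoro. Also open, going by these compounds, is how the swap behaves on a core carrying one anilino group and one benzylamino group.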